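This account rests on a few compounds, and the source may have more. Where it says the series, first, only, none or still open, it means among the compounds named here.

Measured in a functional assay on NCI-H522 cells (Homo sapiens) for inhibition, read by sulforhodamine B assay, with a stated time of 48 h; on this read-out lower numbers stand for stronger inhibition of growth and higher numbers for weaker inhibition of growth:
- Compound 1 `O=C(Cc1csc2nc(-c3ccc(Br)cc3)cn12)N/N=C/c1ccc(O)cc1`: 10700 nM
- Compound 2 `COc1cccc(OC)c1/C=N/NC(=O)Cc1csc2nc(-c3ccc(Br)cc3)cn12`: 22900 nM

Compound 1 holds the lower of these two numbers in this assay. Compound 3 `O=C(Cc1csc2nc(-c3ccc(Br)cc3)cn12)N/N=C/c1ccc(Cl)cc1Cl` has not yet been measured. It differs from compound 1 by 2,4-dichlorophenyl in place of 4-hydroxyphenyl on a carbon with a double bond to nitrogen, with 2,4-dichlorophenyl in place of 4-hydroxyphenyl on a carbon with a double bond to nitrogen. Among the compounds with values here, one measured step bears on this change, replacing the same 4-hydroxyphenyl with 2,6-dimethoxyphenyl: a 2.1-fold higher number from compound 1 to compound 2 (0.33 log units; beyond the scatter), which is modest. A similarly modest rise is therefore expected in this assay, although this single step fixes its direction only loosely. The expected step is a 1.3-fold higher number from compound 1 to compound 3 (0.12 log units; within the scatter). Compound 3 is estimated at 14000 nM, with an expected range of 5000 nM to 40000 nM.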

Compound 3, concentration for 50% growth inhibition: 25700 nM
Compound 3: middle estimate off by 1.8-fold (0.26 log units), on the low side; low and high end bracket the measured number.
By their numbers in this assay, from the lowest: compound 1; then compounds 2 and 3 (each within the scatter of the next).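

In this assay, a second replacement of the 4-hydroxyphenyl, this time by 2,4-dichlorophenyl, also raises the number, with a 2.4-fold higher number from compound 1 to compound 3 (0.38 log units; beyond the scatter), so compound 1 stays lowest against both replacements. The two replacing groups give results that cannot be told apart, with a 1.1-fold higher number from compound 2 to compound 3 (0.05 log units; within the scatter). Nothing available explains these differences. Open, from the compounds shown here alone, is whether the hydroxyl group itself accounts for the lower number of compound 1, and whether an amine or a carboxylic acid at the same place on the phenyl ring would match it.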